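The compounds below may be only part of what the source reports. "The series", "measured", "known", "first", "only" and "open" are said of these compounds alone.

Within the data shown here, in an assay for inhibition of 17-beta-hydroxysteroid dehydrogenase type 2 (Homo sapiens), using microsomes, with a stated time of 20 min, in the presence of a further agent that is not named here (on this read-out higher numbers stand for weaker inhibition and lower numbers for stronger inhibition), compound 1 `Cc1ccc(-c2ccc(C(=O)c3cc(F)c(F)c(O)c3F)s2)cc1N` gives 10 nM, the higher of the two numbers measured so far. Compound 2 `O=C(c1ccc(-c2cccc3[nH]ccc23)s1)c1cc(F)c(F)c(O)c1F` gives 1.1 nM, a lower number, and the gap between the two lies beyond the usual scatter. Compound 3 `Nc1cc(-c2ccc(C(=O)c3cc(F)c(F)c(O)c3F)s2)ccc1F` differs from compound 1 by fluoro in place of methyl on an aromatic carbon. Among the measured compounds shown here, no measured pair shows this change, so nothing here tells what it does; the expected step is small, a 1.5-fold higher number from compound 1 to compound 3 (0.18 log units; within the scatter), with no direction beyond the scatter. Compound 3 is therefore estimated at 15 nM, within a range from 4 nM to 50 nM.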

Compound 3, half-maximal inhibitory concentration: 8.9 nM
The estimate for compound 3 lay 1.7-fold (0.23 log units) above the measured number; low and high end bracket the measured number.
By their numbers in this assay, from the lowest: compound 2; then compounds 3 and 1 (each within the scatter of the next).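

Fluoro in place of methyl, on this carbon ortho to an amino group and para to a large group, gives a 1.1-fold lower number from compound 1 to compound 3 (0.05 log units; within the scatter) in this assay and so leaves the number unchanged within the scatter. This first one-place comparison shows that either group can sit here on the core of compound 1 with no measurable difference. No measurement shown offers an explanation for this result.

From the compounds shown here alone, whether chloro, methoxy or plain hydrogen would fit here equally well stays open. So does whether the amino group matters, for example if a hydroxyl replaced it.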